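Hydroxyphenyl replacing pyridinyl in a topoisomerase 1 series

A few compounds are considered here, and "the series" means these few. Any claim that something is new, unique, unknown or untested is made for them only; others in the source may bear on it.

Measured compounds:
compound 1 `Oc1ccc(-c2cc(-c3ccccc3)cc(-c3ccccc3)n2)cc1`: 52.9%
compound 2 `Oc1ccc(-c2cc(-c3ccccc3)cc(-c3cccnc3)n2)cc1`: 44%

Of the two numbers in an assay on isolated protein for inhibition of DNA topoisomerase 1 (Homo sapiens), with a stated time of 30 min, tested at 100 uM (a higher number here means a stronger effect of the compound at the concentration tested, a lower number a weaker effect), compound 2 holds the lower one, but the step of a number 8.9 percentage points lower from compound 1 to compound 2 (within the scatter) lies within the scatter, so the two compounds are not told apart. Compound 3 `Oc1ccc(-c2cc(-c3ccccc3)cc(-c3ccc(O)cc3)n2)cc1` differs from compound 2 by 4-hydroxyphenyl in place of pyridin-3-yl on an aromatic carbon. Among the compounds with values here, the only measured step, a number 8.9 percentage points lower from compound 1 to compound 2 (within the scatter), also changed the group on that aromatic carbon and stayed within the scatter; no measured step covers 4-hydroxyphenyl there. The step to compound 3 is therefore expected to be a number 6 percentage points higher from compound 2 to compound 3 (within the scatter), not beyond the scatter. Compound 3 is estimated at 50%, in a range from 30% to 70%.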

Compound 3, a percentage reported as inhibition, at one concentration (the size of the read-out at that concentration, not a potency): 0.3%
Beside the measured number, compound 3's estimate is 49.7 percentage points above it, outside the stated range (below it).
By their numbers in this assay, from the lowest: compound 3; then compounds 2 and 1 (each within the scatter of the next).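

In this assay this position next to the ring nitrogen proves sensitive to the group it carries: 4-hydroxyphenyl gives a number 43.7 percentage points lower from compound 2 to compound 3 (beyond the scatter), whereas pyridin-3-yl stayed within the scatter of phenyl. A single hydroxy on that phenyl gives a number 52.6 percentage points lower from compound 1 to compound 3 (beyond the scatter), so this one change separates compound 3 from compound 1. Nothing available explains the drop. Open, from the compounds shown here alone, is whether a methoxy, an amine or a carboxylic acid in place of that hydroxy would leave the read-out as low as in compound 3. Also open, going by these compounds, is whether the same hydroxy elsewhere on that phenyl would do so.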